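The source may hold more compounds than are shown below. What is called first, only, known or untested is meant among the compounds shown, and "the series" means these compounds.

Working notes on a set of amides built on a shared core, tested in a functional assay on UO-31 cells (Homo sapiens) for inhibition, read by sulforhodamine B assay, tested at 10 uM; a lower number here means less inhibition, a higher number more inhibition at the concentration tested (going by the name of the read-out).

Compound 1 `COc1cc2oc(-c3cccc(NC(=O)c4ccc(F)cc4)c3)cc(=O)c2c(OC)c1OC` carries a fluorine on the benzamide ring; in this assay compound 1 is reported as "active" (no number reported). Compound 2 `COc1cc2oc(-c3cccc(NC(=O)c4ccc(Cl)cc4)c3)cc(=O)c2c(OC)c1OC` carries a chlorine in the same position; in this assay compound 2 gives 51.1%. Compound 3 `COc1cc2oc(-c3cccc(NC(=O)c4ccc([N+](=O)[O-])cc4)c3)cc(=O)c2c(OC)c1OC` carries a nitro group; in this assay compound 3 is reported as "active" (no number reported), so there is no single number for compound 3, and compound 1 is the other entry without one. Among the compounds with values here, the only number in the set is therefore that of compound 2, and nothing is known of the size of any step between the measured compounds.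

Compound 4 `COC(=O)c1ccc(C(=O)Nc2cccc(-c3cc(=O)c4c(OC)c(OC)c(OC)cc4o3)c2)cc1` has not yet been run in this assay. It differs from compound 3 in one place (methoxycarbonyl in place of nitro on an aromatic carbon), so the change reads 4-nitrophenyl to 4-(methoxycarbonyl)phenyl on the amide side. Within the data shown here, with no step between measured compounds to lean on, the change is expected to leave this assay read-out near the level seen for compound 2, with no movement beyond the scatter in either direction. Compound 4 is expected to give an estimated 45%, with a range from 20% to 70%.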

Compound 4, a percentage reported as inhibition, at one concentration (the size of the read-out at that concentration, not a potency): "active" (no number reported)
The entry for compound 4 holds no number; the estimate stays without a comparison.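

In this assay, within the data shown here, compound 3 is reported as "active" (no number reported) and compound 4 as "active" (no number reported), so no step between compound 3 and compound 4 can be read. Nothing measured here bears on this result. The compounds shown leave open whether compound 1, compound 3 and compound 4 differ in size of read-out from compound 2, which alone has a number.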